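Swapping butyl for isopropylcarbonyl on a cytotoxic sulfoxide series

The source may hold more compounds than are shown below. What is called first, only, known or untested is meant among the compounds shown, and "the series" means these compounds.

Values in a functional assay on A549 cells (Homo sapiens) for cytotoxicity, with a stated time of 48 h; a lower number here means a stronger inhibitor, a higher number a weaker inhibitor:
- compound 1 `Cc1ccc2oc(/C=C/[S+](C)[O-])cc(=O)c2c1`: 1700 nM
- compound 2 `Cc1cccc2oc(/C=C/[S+](C)[O-])cc(=O)c12`: 1300 nM
- compound 3 `CCCCOc1ccc2oc(/C=C/[S+](C)[O-])cc(=O)c2c1`: 1400 nM

Compound 3, at 1400 nM, lies within the scatter of both compound 1 and compound 2, so the three cannot be ranked. Compound 4 `CC(C)C(=O)Oc1ccc2oc(/C=C/[S+](C)[O-])cc(=O)c2c1` has isopropylcarbonyl in place of butyl on an oxygen on an aromatic ring. Among the measured compounds shown here, no measured compound carries this group, so the evidence is indirect. For the measured compounds named here, the only measured step, butoxy in place of methyl on an aromatic carbon, gave a 1.2-fold lower number from compound 1 to compound 3 (0.08 log units; within the scatter). That small step suggests this position tolerates change in this assay, though one step is thin support. The expected step is a 1.1-fold higher number from compound 3 to compound 4 (0.03 log units; within the scatter), with no clear change beyond the scatter. The estimate for compound 4 is 1500 nM, with an expected range of 700 nM to 3200 nM.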

Compound 4, half-maximal inhibitory concentration: 2400 nM
Estimate against measurement, compound 4: 1.6-fold (0.20 log units) below; low and high end bracket the measured number.
By their numbers in this assay, from the lowest: compounds 2, 3, 1 and 4 (each within the scatter of the next).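

In this assay isopropylcarbonyl in place of butyl gives a 1.7-fold higher number from compound 3 to compound 4 (0.23 log units; within the scatter) and (isopropylcarbonyl)oxy in place of methyl gives a 1.4-fold higher number from compound 1 to compound 4 (0.15 log units; within the scatter) so neither change moves the number clearly. The earlier compounds shown here showed this tolerance only for methyl and butoxy; it now extends to a group carrying a carbonyl and a hydrogen-bond acceptor. Still open, as far as these compounds go, is whether an amine, a carboxylic acid or a chain longer than butyl on this oxygen would shift the number beyond the scatter. No supporting measurement is available to explain these small differences.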